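A few compounds are considered here, and "the series" means these few. Any claim that something is new, unique, unknown or untested is made for them only; others in the source may bear on it.

Of the compounds shown here, two have so far been measured in a functional assay on SW-620 cells (Homo sapiens) for antiproliferative activity, with a stated time of 48 h; a higher number here means a weaker inhibitor of growth, a lower number a stronger inhibitor of growth. Compound 1 `Cc1cc(O)c(C2=NN(c3ccc(S(N)(=O)=O)cc3)C(c3ccccc3O)C2)cc1Cl` gives 1760 nM, and compound 2 `Cc1cc(O)c(C2=NN(c3ccc(S(N)(=O)=O)cc3)C(c3ccccc3Cl)C2)cc1Cl` gives 1970 nM. The two numbers lie within the scatter of each other, so compound 2 stands level with compound 1 rather than apart from it. Within the data shown here, the only measured step, a 1.1-fold higher number from compound 1 to compound 2 (0.05 log units; within the scatter), swaps a hydroxy for a chloro on an aromatic carbon and changes little.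

Compound 3 `Cc1cc(O)c(C2=NN(c3ccc(S(N)(=O)=O)cc3)C(/C=C/c3ccccc3)C2)cc1Cl` has not yet been measured. It differs from compound 2 by 2-phenylethenyl in place of 2-chlorophenyl on a saturated ring carbon: a 2-phenylethenyl in place of a 2-chlorophenyl on a saturated ring carbon. Among the measured compounds shown here, no measured step touches that carbon, so the single known step gives no direct guide to this change, and nothing in the data points to a shift in either direction. The expected step is therefore a 1.0-fold higher number from compound 2 to compound 3 (0.01 log units; within the scatter), nothing beyond the scatter. Compound 3 is estimated to give 2000 nM in this assay, within a range from 600 nM to 7000 nM.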

Compound 3, concentration for 50% growth inhibition: 11700 nM
Beside the measured number, compound 3's estimate is 5.9-fold (0.77 log units) below it; the whole stated range lies below it.
By their numbers in this assay, from the lowest: compounds 1 and 2 (each within the scatter of the next); then compound 3.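

In this assay, the saturated ring carbon next to the ring nitrogen proves sensitive to which group it carries: 2-phenylethenyl in place of 2-chlorophenyl gives a 5.9-fold higher number from compound 2 to compound 3 (0.77 log units; beyond the scatter), and in place of 2-hydroxyphenyl it gives a 6.6-fold higher number from compound 1 to compound 3 (0.82 log units; beyond the scatter). The earlier swap of hydroxy for chloro on the attached aromatic ring stayed within the scatter, whereas replacing the whole group here weakens growth inhibition beyond it. The data offer no measured explanation for this loss.

Compound 3 adds a double bond and loses the substituent on the aromatic ring in a single step, so the contribution of each remains unresolved. A plain phenyl group and a saturated 2-phenylethyl chain at this carbon would help separate the two contributions.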